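The source may hold more compounds than are shown below. What is called first, only, known or untested is meant among the compounds shown, and "the series" means these compounds.

Measured in an ADME assay on L02 cells (Homo sapiens) for cytotoxicity, read by MTT assay, with a stated time of 48 h; a lower number here means a stronger inhibitor, a higher number a weaker inhibitor:
Compound 1 `CCN1CCN(C[C@H]2CN(c3ccc(-n4cc(-c5ccccn5)cn4)c(F)c3)C(=O)O2)CC1` gives 99 ug/mL.
Compound 2 `O=C1O[C@@H](CN2CCCCC2)CN1c1ccc(-n2cc(-c3ccccn3)cn2)c(F)c1` gives > 400 ug/mL, a limit of the assay rather than a number.
Compound 3 `O=C1CCC(=O)N1C[C@H]1CN(c2ccc(-n3cc(-c4ccccn4)cn3)c(F)c2)C(=O)O1` gives > 400 ug/mL, again only a limit.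

Two of the three readings therefore sit at the ceiling of the assay (the limit of > 400 ug/mL in this assay, at which 2 of the 3 values shown sit), and compound 3 is one of them. Compound 4 `O=C(OC[C@H]1CN(c2ccc(-n3cc(-c4ccccn4)cn3)c(F)c2)C(=O)O1)c1ccccc1` differs from compound 3 by benzoyloxy in place of 2,5-dioxopyrrolidin-1-yl on a saturated chain carbon bound to a saturated ring carbon. Of the steps already measured, an at least 4.0-fold higher number from compound 1 to compound 3 (0.60 log units; beyond the scatter) shows that changing the group at this position can push the reading beyond range, whereas a step that the two limits leave unreadable from compound 2 to compound 3 gives no readable size. In this assay no step beyond the scatter is expected for compound 4, which is estimated at 300 ug/mL (range 100 ug/mL to 400 ug/mL). That estimate means an expected at least 1.3-fold lower number from compound 3 to compound 4 (0.12 log units; that floor lies within the scatter).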

Compound 4, half-maximal inhibitory concentration: > 400 ug/mL
Compound 4 ended at the assay's limit; the forecaster's own chance of this, stated with the estimate: 55%; at least 1.3-fold (0.12 log units) between middle value and limit.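

In this assay, benzoyloxy in place of 4-ethylpiperazin-1-yl gives an at least 4.0-fold higher number from compound 1 to compound 4 (0.60 log units; beyond the scatter), so a group with a carbon-only aromatic ring now joins piperidin-1-yl and 2,5-dioxopyrrolidin-1-yl at the ceiling. Compound 1 remains the only one of the four with a true number. The steps among compound 2, compound 3 and compound 4 cannot be read because all three readings are limits: the limit of > 400 ug/mL in this assay, at which 3 of the 4 values shown sit.

From the compounds shown here alone, whether morpholin-4-yl, dimethylamino or a free hydroxyl at this place would read below the limit stays open. So does how far beyond it compound 2, compound 3 and compound 4 lie.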